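Replacing the Urea Link: A Weaker Effect Expected

The compounds below may be only part of what the source reports. "The series", "measured", "known", "first", "only" and "open" are said of these compounds alone.

In a functional assay on COLO 205 cells (Homo sapiens) for inhibition, read by sulforhodamine B assay, with a stated time of 48 h, tested at 10 uM (on this read-out higher numbers stand for a weaker effect at the one concentration tested and lower numbers for a stronger effect), compound 1 `COc1cc(Cl)cc(-c2nn(-c3cccc(NC(=O)Nc4cccc(C(F)(F)F)c4)c3)cc2-c2ccncc2)c1` gives -31.2%.
In this assay compound 2 `COc1cc(Cl)cc(-c2nn(-c3cccc(NC(=O)Nc4ccc(Cl)c(C(F)(F)F)c4)c3)cc2-c2ccncc2)c1` gives -48.3%.
In this assay compound 3 `COc1cc(Cl)cc(-c2nn(-c3cccc(NC(=O)c4cc(C(F)(F)F)cc(C(F)(F)F)c4)c3)cc2-c2ccncc2)c1` gives 88.7%.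

Compound 2 stands lowest of the three, the strongest effect seen here; the step of a number 17.1 percentage points lower from compound 1 to compound 2 (beyond the scatter) is the only one measured. Compound 4 `COc1cc(Cl)cc(-c2nn(-c3cccc(NC(=O)c4ccc(Cl)c(Cl)c4)c3)cc2-c2ccncc2)c1` differs from compound 2 by 3,4-dichlorophenyl in place of (4-chloro-3-(trifluoromethyl)phenyl)amino on a carbonyl carbon. The measured step concerns a chloro in place of hydrogen and does not bear on this change. Among the measured compounds shown here, the only guide is compound 3, which also carries an amide on that carbonyl carbon and gives 88.7%. On that basis compound 4 is expected near 70%, with a range from 30% to 100%. That estimate means an expected step of a number 118.3 percentage points higher from compound 2 to compound 4 (beyond the scatter).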

Compound 4, a percentage reported as activity, at one concentration (the size of the read-out at that concentration, not a potency): 81.5%
Compound 4: middle estimate off by 11.5 percentage points, on the low side; the measured number falls inside the stated range.
By their numbers in this assay, from the lowest: compound 2; then compound 1; then compounds 4 and 3 (each within the scatter of the next).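

At this carbonyl carbon, 3,4-dichlorophenyl in place of (4-chloro-3-(trifluoromethyl)phenyl)amino gives a number 129.8 percentage points higher from compound 2 to compound 4 (beyond the scatter) in this assay and in place of (3-(trifluoromethyl)phenyl)amino gives a number 112.7 percentage points higher from compound 1 to compound 4 (beyond the scatter) in the same read-out. The change is therefore large from both ureas, whether or not the chloro of compound 2 is present. Nothing measured here accounts for the size of these steps.

As far as these compounds go, it remains open whether a thiourea or a sulfonamide at this link would keep the effect of compound 2.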